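This account rests on a few compounds, and the source may have more. Where it says the series, first, only, none or still open, it means among the compounds named here.

Measured in a functional assay on brain (Rattus norvegicus, strain Wistar) for inhibition; on this read-out lower numbers stand for stronger inhibition and higher numbers for weaker inhibition:
- compound 1 `CCCCc1ccc(-c2c(C)[nH]c(=O)n2C2CCCCC2)cc1`: 27100 nM
- compound 2 `CCCCCOc1ccc(-c2c(C)[nH]c(=O)n2C)cc1`: 4500 nM
- compound 3 `CCCCCOc1ccc(-c2c(C)[nH]c(=O)n2C2CCCCC2)cc1`: 9100 nM

Compound 3 lies between the other two, second highest of the three numbers. The next structure, compound 4 `CCCCCCCCCCOc1ccc(-c2c(C)[nH]c(=O)n2C2CCCCC2)cc1`, carries pentyl in place of hydrogen on a saturated chain carbon, five bonds along the chain from an oxygen on an aromatic ring, a longer chain on the oxygen. The closest measured precedent is a change in that same substituent, a 3.0-fold lower number from compound 1 to compound 3 (0.47 log units; beyond the scatter), which is modest and goes to the lower number. The other step, a 2.0-fold higher number from compound 2 to compound 3 (0.31 log units; beyond the scatter), changes the group on the aromatic nitrogen, so it bears on this change only weakly. No chain this long has been measured, so the direction rests on a single step. A modest step towards a lower number in this assay is expected. The expected step is a 3.0-fold lower number from compound 3 to compound 4 (0.48 log units; beyond the scatter). For compound 4 the estimated value is 3000 nM, with an expected range of 700 nM to 12000 nM.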

Compound 4, half-maximal inhibitory concentration: 10500 nM
Estimate against measurement, compound 4: 3.5-fold (0.54 log units) below; the range from low to high includes it.
By their numbers in this assay, from the lowest: compound 2; then compounds 3 and 4 (each within the scatter of the next); then compound 1.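

In this assay, pentyl in place of hydrogen on a saturated chain carbon, five bonds along the chain from an oxygen on an aromatic ring, gives a 1.2-fold higher number from compound 3 to compound 4 (0.06 log units; within the scatter). The added length therefore brings no change distinguishable from scatter, and the earlier gain, a 3.0-fold lower number from compound 1 to compound 3 (0.47 log units; beyond the scatter), does not carry over to this step. No measurement offered here accounts for this result.

Chains of intermediate length, such as heptyloxy, remain open. So does the effect of an amine or a carboxylic acid on this chain.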